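Extending the alkoxy group on a sulfide:quinone oxidoreductase inhibitor

This account rests on a few compounds, and the source may have more. Where it says the series, first, only, none or still open, it means among the compounds named here.

Compound 1 `COc1ccccc1-c1cc(-c2ccc(F)cc2)c(C#N)c(OC)n1`: 75 nM
Compound 2 `COc1nc(-c2ncccc2C)cc(-c2ccc(F)cc2)c1C#N`: 8.7 nM

In an assay on isolated protein for inhibition of sulfide:quinone oxidoreductase, mitochondrial (Homo sapiens) (a lower number here means a stronger inhibitor, a higher number a weaker inhibitor), compound 2 gives the lower of the two numbers, and the step of an 8.6-fold lower number from compound 1 to compound 2 (0.94 log units; beyond the scatter) lies beyond the scatter. Compound 3 `Cc1cccnc1-c1cc(-c2ccc(F)cc2)c(C#N)c(OCc2cccnc2)n1` differs from compound 2 by pyridin-3-yl in place of hydrogen on a saturated chain carbon bound to an oxygen on an aromatic ring. For the measured compounds named here, the only measured step, from compound 1 to compound 2, concerns a different position, so no measured step bears directly on this change. With nothing to indicate otherwise, compound 3 is expected to stay close to compound 2, with a step of a 1.7-fold higher number from compound 2 to compound 3 (0.24 log units; within the scatter), and its estimate in this assay is 15 nM, ranging from 4 nM to 60 nM.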

Compound 3, half-maximal inhibitory concentration: 36 nM
Compound 3: middle estimate off by 2.4-fold (0.38 log units), on the low side; low and high end bracket the measured number.
By their numbers in this assay, from the lowest: compound 2; then compound 3; then compound 1.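

In this assay, for the compounds shown here, the change from methoxy to (pyridin-3-yl)methoxy gives a 4.1-fold higher number from compound 2 to compound 3 (0.62 log units; beyond the scatter), the first reading at this position. The step is a loss beyond the scatter, but a modest one, so this position tolerates the added ring, and compound 3 still reads 36 nM. No evidence at hand accounts for the step. The compounds shown leave open whether the loss follows from the pyridin-3-yl ring or from the longer group as such. An ethoxy or benzyloxy group at the same place would help separate the two.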